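Series notes: removing the (1,3-dicarboxypropyl)amino group

The source may hold more compounds than are shown below. What is called first, only, known or untested is meant among the compounds shown, and "the series" means these compounds.

compound 1 `Nc1nc2[nH]c(CCCCCCCCC(=O)N[C@@H](CCC(=O)O)C(=O)O)cc2c(=O)[nH]1`: 1.48 nM
compound 2 `Nc1nc2[nH]c(CCCCCC(=O)O)cc2c(=O)[nH]1`: > 1000 nM (a limit)

Among the compounds with values here, compound 1 is the only compound with a numeric result in a functional assay on KB cells (Homo sapiens) for inhibition, read by CellTiter-Blue, with a stated time of 96 h; a higher number here means a weaker inhibitor, a lower number a stronger inhibitor. The result for compound 2 is only a limit: the limit of > 1000 nM in this assay, at which 1 of the 2 values shown sits.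

Compound 3 `Nc1nc2[nH]c(CCCCCCCCC(=O)O)cc2c(=O)[nH]1` differs from compound 1 in one place: hydroxy in place of (1,3-dicarboxypropyl)amino on a carbonyl carbon, with hydroxy in place of (1,3-dicarboxypropyl)amino on a carbonyl carbon. Within the data shown here, no measured step covers this change. Compound 2, which also lacks that group, gives only the limit > 1000 nM. A large rise in the number, well beyond the scatter, is therefore expected in this assay. The estimated change is a 1000-fold higher number from compound 1 to compound 3 (3.01 log units; beyond the scatter). For compound 3 the expected value is 1500 nM, with an expected range of 250 nM to 10000 nM.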

Compound 3, half-maximal inhibitory concentration: > 1000 nM
Compound 3 gave a limit, no number (the forecaster's own chance of this, stated with the estimate: 75%); the middle value is on the limit's open side.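

With the chain of compound 1 kept, the (1,3-dicarboxypropyl)amino group on the carbonyl carbon is now tested alone: in this assay, hydroxy in its place gives an at least 670-fold higher number from compound 1 to compound 3 (2.82 log units; beyond the scatter). The result for compound 3 is a limit, so this step is a minimum. The step between compound 2 and compound 3 cannot be read, since both results are limits: the limit of > 1000 nM in this assay, at which 2 of the 3 values shown sit.

Going by these compounds, it remains open which part of the departing group matters. A simple primary amide, or an amide carrying a single carboxylic acid, could separate these parts.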